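The source may report more compounds than this note shows. Statements on the series, on what has been measured and on what is new or still open speak of the compounds shown alone.

Working notes on the series.

Measured so far in an assay on isolated protein for inhibition of thiosulfate sulfurtransferase (Homo sapiens), with a stated time of 60 min, in the absence of a further agent; on this read-out lower numbers stand for stronger inhibition and higher numbers for weaker inhibition:
- compound 1 `COc1c(Br)cc(Br)cc1C(=O)Nc1ccccc1`; in this assay compound 1 gives > 100000 nM, which is a limit of the assay and not a number.
- compound 2 `COc1c(Br)cc(Br)cc1C(=O)Nc1cccc(Cl)c1`; in this assay compound 2 gives > 100000 nM, again a limit.
- compound 3 `O=C(Nc1cccc(Cl)c1)c1cccc(Br)c1O`; in this assay compound 3 gives > 100000 nM, again a limit.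

Compound 2 and compound 1 differ in one place: hydrogen in place of chloro on an aromatic carbon. The step that the two limits leave unreadable from compound 2 to compound 1 is not readable, as both values are limits. How the core of compound 3 differs from the core of compound 2 is not broken down here.

Compound 4 `O=C(Nc1ccccc1)c1cccc(Br)c1O` has not been measured in this assay. It differs from compound 3 by hydrogen in place of chloro on an aromatic carbon; this is the same change as that made from compound 2 to compound 1, at a place described in the same words in both cases.

Expectation for compound 4 in this assay: the one occurrence of this change already seen gave no readable step, and all three values so far sit together at the limit (the limit of > 100000 nM in this assay, at which 3 of the 3 values shown sit). On that basis the expected step from compound 3 to compound 4 is a step that the limit leaves unreadable from compound 3 to compound 4, and compound 4 is most likely to return a limit rather than a number. The estimate for compound 4 in this assay is 150000 nM, with an expected range from 50000 nM to 500000 nM.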

Compound 4, half-maximal inhibitory concentration: > 100000 nM
Compound 4 gave a limit, no number (the forecaster's own chance of this, stated with the estimate: 85%); the middle value lies beyond the limit too.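

In this assay compound 4 gives > 100000 nM, a limit and not a number. No new step can be read from compound 3 to compound 4, as both values are limits, and the whole series sits together: the limit of > 100000 nM in this assay, at which 4 of the 4 values shown sit. The compounds shown leave open how large the change from chloro to hydrogen on the aromatic carbon is, and what inhibition any of these four compounds actually has.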